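The source may report more compounds than this note shows. Statements on the series, on what has been measured and on what is new or still open speak of the compounds shown alone.

Among the measured compounds shown here, in a functional assay on the whole organism (strain Wistar) for inhibition, with Rattus norvegicus as the target, read by paw edema, with stated times of 60 min and 4 h, at a dose of 100 mg/kg by the oral route (a higher number here means more inhibition at the dose given (going by the name of the read-out), a lower number less inhibition), compound 1 `COc1cc2c(cc1OC)C(CC(=O)NC(C)C)CC2` gives 39.1%, and compound 2 `CCCCNC(=O)CC1CCc2cc(OC)c(OC)cc21` gives 25%, the lowest of the two numbers known; the only measured step, a number 14.1 percentage points lower from compound 1 to compound 2 (beyond the scatter), is modest but beyond the scatter. Compound 3 `COc1cc2c(cc1OC)C(CC(=O)NC(C)(C)C)CC2` differs from compound 2 in one place: tert-butyl in place of butyl on an amide-type nitrogen. That step bears only loosely on the one measured, since a branched group replaces a straight one on the amide-type nitrogen, and compound 1 with its isopropyl gave the higher number. Compound 3 is therefore expected to rise by a number 8 percentage points higher from compound 2 to compound 3 (within the scatter), to an estimated 33% in this assay, within a range from 15% to 50%.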

Compound 3, a percentage reported as inhibition, in the whole organism at one dose (the size of the read-out at that dose, not a potency): 32.8%
Estimate against measurement, compound 3: 0.2 percentage points above; the measured number falls inside the stated range.
By their numbers in this assay, from the lowest: compounds 2, 3 and 1 (each within the scatter of the next, the first and the last beyond it).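

In this assay tert-butyl in place of butyl on the amide-type nitrogen gives a number 7.8 percentage points higher from compound 2 to compound 3 (within the scatter) and the added methyl gives a number 6.3 percentage points lower from compound 1 to compound 3 (within the scatter) as the other step. Both steps lie within the scatter, so compound 3 cannot be told apart from compound 1 or compound 2, even though those two differ beyond it. Nothing at hand explains these numbers. On these data alone, what cyclohexyl, a longer chain or an amine on this nitrogen would give stays open, as does whether any such group would clear the scatter.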